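Amino in Place of Hydrogen on the 1H-Pyrazol-4-yl Group

A few compounds are considered here, and "the series" means these few. Any claim that something is new, unique, unknown or untested is made for them only; others in the source may bear on it.

All compounds share one core. Compound 2 `Fc1ccc(-c2nn3c(NC4CCCC4)cccc3c2-c2ccc3[nH]ccc3c2)cc1` gives 20000 nM in an ADME assay on Vero cells (Chlorocebus sabaeus) for cytotoxicity (a lower number here means that less compound is tolerated, a higher number that more compound is tolerated), and compound 3 `Fc1ccc(-c2nn3c(NC4CCCC4)cccc3c2-c2cn[nH]c2)cc1` gives 10000 nM; the step of a 2.0-fold lower number from compound 2 to compound 3 (0.30 log units; within the scatter) lies within the scatter, so compound 3 stands lowest of the two numbers without being set apart from compound 2. For compound 1 `Fc1ccc(-c2nn3c(NC4CCCC4)cccc3c2-c2ccoc2)cc1` the result in this assay is "not determined" (no result reported). Compound 4 `Nc1n[nH]cc1-c1c(-c2ccc(F)cc2)nn2c(NC3CCCC3)cccc12` differs from compound 3 by amino in place of hydrogen on an aromatic carbon. For the measured compounds named here, no measured step concerns this change; the only step at hand, a 2.0-fold lower number from compound 2 to compound 3 (0.30 log units; within the scatter), exchanged 1H-indol-5-yl for 1H-pyrazol-4-yl and stayed within the scatter, so no step beyond the scatter is expected in this assay here either. Compound 4 is therefore estimated at 10000 nM, between 4000 nM and 25000 nM. The step of no change at the digits printed from compound 3 to compound 4 (within the scatter) is thus expected to stay within the scatter.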

Compound 4, half-maximal cytotoxic concentration: 20000 nM
Compound 4: the middle estimate sits 2.0-fold (0.30 log units) below what was measured; low and high end bracket the measured number.
By their numbers in this assay, from the lowest: compounds 3, 2 and 4 (each within the scatter of the next).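

Going from 1H-pyrazol-4-yl to 3-amino-1H-pyrazol-4-yl gives a 2.0-fold higher number from compound 3 to compound 4 (0.30 log units; within the scatter) in this assay, so this aromatic carbon, next to the ring nitrogen, takes an amino group without a step beyond the scatter. Exchanging 1H-indol-5-yl for 3-amino-1H-pyrazol-4-yl gives no change at the digits printed from compound 2 to compound 4 (within the scatter), so the aminated five-membered ring and the indolyl group cannot be told apart here. No supporting evidence bears on these results. Open, going by these compounds, is whether a dimethylamino group, an acetamide or a carboxylic acid on this same carbon would also stay within the scatter.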